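Sulfonamide substituent exchange on a shared chromene core

The compounds below may be only part of what the source reports. "The series", "measured", "known", "first", "only" and "open" are said of these compounds alone.

Measured compounds:
Compound 1 `COc1ccc(NS(=O)(=O)c2ccc3c(c2)C(n2ccccc2=O)=CC(C)(C)O3)cc1` gives 77.9% in a functional assay on the whole organism (aorta) with Rattus norvegicus as the target; on this read-out higher numbers stand for larger maximal responses and lower numbers for smaller maximal responses.
Compound 2 `CN(c1ccccc1)S(=O)(=O)c1ccc2c(c1)C(n1ccccc1=O)=CC(C)(C)O2` gives 64.2% in this assay.

Among the two compounds measured, compound 2 stands lowest in this assay; its nearest neighbour is compound 1, and the only step between them, a number 13.7 percentage points lower from compound 1 to compound 2 (beyond the scatter), is beyond the scatter and modest in size.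

The step now followed leads from compound 2 to compound 3 `CC1(C)C=C(n2ccccc2=O)c2cc(S(=O)(=O)NC(=O)Nc3ccccc3)ccc2O1`. The change is (phenylcarbamoyl)amino in place of methyl(phenyl)amino on a sulfonyl sulfur.

Going by the values given here, the one measured step that bears on this is the replacement at the same sulfonyl sulfur, a number 13.7 percentage points lower from compound 1 to compound 2 (beyond the scatter), where a group carrying an amino hydrogen gave way to methyl(phenyl)amino and the maximal response fell. The change into compound 3 runs in the opposite sense as far as hydrogen-bond donors are counted, so a modest rise back toward the level of compound 1 is expected, though the new group differs in more than that and the expectation is loose.

Compound 3 is therefore estimated at 74%, within 58% to 90%; this means an expected step of a number 9.8 percentage points higher from compound 2 to compound 3 (within the scatter).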

Compound 3, largest response reached (Emax), in percent of the reference or control that the assay uses: 90.8%
Compound 3: the middle estimate sits 16.8 percentage points below what was measured; the whole stated range lies below it.
By their numbers in this assay, from the lowest: compound 2; then compound 1; then compound 3.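

In this assay, the sulfonyl sulfur proves able to carry a group that lifts the maximal response past the level of compound 1, not merely back to it: the exchange of methyl(phenyl)amino for (phenylcarbamoyl)amino gives a number 26.6 percentage points higher from compound 2 to compound 3 (beyond the scatter). The sulfonamide nitrogen keeps its hydrogen in both of the other compounds, yet replacing 4-methoxyphenyl with phenylcarbamoyl on that nitrogen still gives a number 12.9 percentage points higher from compound 1 to compound 3 (beyond the scatter), so among these three compounds the group on that nitrogen matters beyond the presence of that hydrogen, and compound 3 ends as the highest, with both of its steps beyond the scatter. No measurement on hand explains either rise, so the result stands as an observation about these structures alone.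

The compounds shown cannot separate the contribution of the carbonyl from that of the terminal phenylamino part, which a simple acetyl or benzoyl group on the sulfonamide nitrogen would begin to address. They also leave open whether a methyl group on the sulfonamide nitrogen of compound 3 would lower the response, and whether a cyclohexyl group could stand in for the terminal phenyl.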